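The compounds below may be only part of what the source reports. "The series", "measured", "known", "first", "only" and "open" are said of these compounds alone.

Compound 1 `Cc1ccc(Cn2cc(COc3ccc4c(=O)ccoc4c3)nn2)cc1`: 10400 nM in a functional assay on SW480 cells (Homo sapiens) for cytotoxicity, read by MTT assay, with a stated time of 48 h; a lower number here means a stronger inhibitor, a higher number a weaker inhibitor
Compound 2 `O=c1ccoc2cc(OCc3cn(Cc4ccccc4Br)nn3)ccc12`: > 100000 nM in this assay (a limit, not a number)

In this assay compound 1 gives 10400 nM. For compound 2 this assay reports only a limit, > 100000 nM. Among the measured compounds shown here, the one measured step, an at least 9.6-fold higher number from compound 1 to compound 2 (0.98 log units; beyond the scatter), is therefore an open-ended rise, and compound 2 stands at the limit of > 100000 nM in this assay, at which 1 of the 2 values shown sits; nothing shows how far beyond that limit its true number lies.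

Compound 3 `N#Cc1cccc(Cn2cc(COc3ccc4c(=O)ccoc4c3)nn2)c1` differs from compound 2 by 3-cyanophenyl in place of 2-bromophenyl on a saturated chain carbon bound to an aromatic nitrogen. For the measured compounds named here, no measured step covers a nitrile on this ring, nor a move of the substituent from one position on the ring to another, so the step of an at least 9.6-fold higher number from compound 1 to compound 2 (0.98 log units; beyond the scatter) is the only guide: exchanging the group on the saturated chain carbon bound to the aromatic nitrogen can shift this assay strongly. Because compound 2 already sits at the limit of > 100000 nM in this assay, at which 1 of the 2 values shown sits, a further rise beyond the scatter could not be seen, and the expected step is an at least 2.0-fold lower number from compound 2 to compound 3 (0.30 log units; that floor lies within the scatter), a fall back toward the region of compound 1. Compound 3 is estimated at 50000 nM, expected between 10000 nM and 150000 nM.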

Compound 3, half-maximal inhibitory concentration: > 100000 nM
Compound 3 gave a limit, no number (the forecaster's own chance of this, stated with the estimate: 40%); middle value at least 2.0-fold (0.30 log units) away from the limit.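

In this assay, a second replacement of 4-methylphenyl on the saturated chain carbon bound to an aromatic nitrogen now gives an at least 9.6-fold higher number from compound 1 to compound 3 (0.98 log units; beyond the scatter), so the rise no longer rests on 2-bromophenyl alone. The 3-cyanophenyl group, with its nitrile and its different place on the ring, does not bring the read-out back into the measurable range, and the step between compound 2 and compound 3 cannot be read, as both values are limits. Of the three compounds, only compound 1, with 4-methylphenyl, has a number, while the other two rest at one limit: the limit of > 100000 nM in this assay, at which 2 of the 3 values shown sit.

The compounds shown leave open whether the number of compound 1 goes with the methyl group itself or with its place on the ring, and whether 2-bromophenyl and 3-cyanophenyl differ at all beyond the limit. Going by these compounds, how a plain phenyl, 4-chlorophenyl or 4-cyanophenyl group would read at this position is also open, as is whether any group there would give a lower number than compound 1 does at 10400 nM.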